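The source may report more compounds than this note shows. Statements on the series, on what has been measured and on what is new or still open speak of the compounds shown alone.

Measured compounds: compound 1 `O=Cc1cccc(C#Cc2ccc(CCC(=O)O)cc2)c1` gives 355 nM in an in vitro functional assay on 1321-N1 cells for agonist activity at Free fatty acid receptor 1 (Homo sapiens), read by fluorescence; on this read-out higher numbers stand for an effect only at larger amounts of compound and lower numbers for an effect already at smaller amounts; compound 2 `Cc1cccc(C#Cc2ccc(CCC(=O)O)cc2)c1` gives 43.7 nM; compound 3 `Cc1cc(C)cc(C#Cc2ccc(CCC(=O)O)cc2)c1` gives 74.1 nM.

Among these three, compound 2 stands lowest in this assay: compound 3 sits close by, as a 1.7-fold higher number from compound 2 to compound 3 (0.23 log units; within the scatter) shows, while compound 1 sits far above, as an 8.1-fold lower number from compound 1 to compound 2 (0.91 log units; beyond the scatter) shows in reverse.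

Compound 4 `N#Cc1cccc(C#Cc2ccc(CCC(=O)O)cc2)c1` has not yet been measured. It differs from compound 2 in one place: cyano in place of methyl on an aromatic carbon. Going by the values given here, two measured steps bear on this. The step from compound 1 to compound 2 was an 8.1-fold lower number from compound 1 to compound 2 (0.91 log units; beyond the scatter), a modest change when a formyl group gave way to methyl at this position. The step of a 1.7-fold higher number from compound 2 to compound 3 (0.23 log units; within the scatter) showed that adding a methyl elsewhere changed little. Among the compounds with values here, compound 4 moves away from methyl again, toward a group other than methyl, so a higher number than compound 2 is expected, though with only one such comparison the size is uncertain. For compound 4 the expected step is a 3.4-fold higher number from compound 2 to compound 4 (0.54 log units; beyond the scatter). Compound 4 is therefore estimated at 150 nM, within a range from 55 nM to 420 nM.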

Compound 4, half-maximal effective concentration: 91.2 nM
Compound 4: middle estimate off by 1.6-fold (0.22 log units), on the high side, and the stated range covers the measured number.
By their numbers in this assay, from the lowest: compounds 2, 3 and 4 (each within the scatter of the next, the first and the last beyond it); then compound 1.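

In this assay, this position now offers three groups to compare, and each swap makes a difference: cyano in place of methyl gives a 2.1-fold higher number from compound 2 to compound 4 (0.32 log units; beyond the scatter), while cyano in place of formyl gives a 3.9-fold lower number from compound 1 to compound 4 (0.59 log units; beyond the scatter). Leaving methyl therefore carries no single fixed cost, since the size of the change depends on the group that enters, and among these three groups methyl gives the lowest number and formyl the highest. No evidence at hand bears on why the groups fall in this order.

Still open, as far as these compounds go, is where other groups would fall at this position, such as an amine, a carboxylic acid, a chlorine atom or a longer chain like ethyl. Also open, from the compounds shown here alone, is whether the same order would hold on the core of compound 3, which carries a second methyl.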